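Swapping the ring on the hydrazide side of a dibenzoylhydrazine

This account rests on a few compounds, and the source may have more. Where it says the series, first, only, none or still open, it means among the compounds named here.

Three measured compounds share one core and differ only in the group on one aromatic ring. In an assay on cells for agonist activity at ecdysone receptor (Bombyx mori), read by a luciferase reporter, with a stated time of 24 h (a higher number here means that more compound is needed for the effect, a lower number that less compound is needed), compound 3 `Cc1ccc(C(=O)NN(C(=O)c2ccccc2Cl)C(C)(C)C)cc1` gives 18.6 nM, the lowest number of the set. Compound 1 `CC(C)(C)N(NC(=O)c1ccc(Cl)cc1)C(=O)c1ccccc1Cl` gives 115 nM in this assay, and compound 2 `CC(C)(C)N(NC(=O)c1ccc(C#N)cc1)C(=O)c1ccccc1Cl` gives 603 nM. The steps are a 6.2-fold lower number from compound 1 to compound 3 (0.79 log units; beyond the scatter) and a 32-fold lower number from compound 2 to compound 3 (1.51 log units; beyond the scatter). Compound 4 `CC(C)(C)N(NC(=O)c1cccc(Cl)c1Cl)C(=O)c1ccccc1Cl` brings a different change: 2,3-dichlorophenyl in place of 4-methylphenyl on a carbonyl carbon. Among the compounds with values here, no measured step covers a second chlorine or a ring with two substituents, so only the move from methyl to a single chloro, a 6.2-fold lower number from compound 1 to compound 3 (0.79 log units; beyond the scatter), bears on it. Compound 4 is therefore expected to need more compound than compound 3, with an estimated step of an 8.1-fold higher number from compound 3 to compound 4 (0.91 log units; beyond the scatter). Compound 4 is estimated at 150 nM in this assay, within a broad range from 30 nM to 800 nM.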

Compound 4, half-maximal effective concentration: 9.33 nM
Compound 4: the middle estimate sits 16-fold (1.21 log units) above what was measured; the measured number lies below the stated range.
By their numbers in this assay, from the lowest: compounds 4 and 3 (each within the scatter of the next); then compound 1; then compound 2.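

In this assay, placing 2,3-dichlorophenyl on this carbonyl carbon gives a number that cannot be told apart from that of 4-methylphenyl, with a 2.0-fold lower number from compound 3 to compound 4 (0.30 log units; within the scatter) in the scatter-level comparison. A ring with two chlorines is therefore compatible with activity here, and it separates clearly from 4-chlorophenyl, with a 12-fold lower number from compound 1 to compound 4 (1.09 log units; beyond the scatter) on that step, and from 4-cyanophenyl, with a 65-fold lower number from compound 2 to compound 4 (1.81 log units; beyond the scatter) on that step. No measurement offered here gives a reason for these steps.

The compounds shown leave open which of the two chlorines matters more. They also leave open how 2,3-dimethylphenyl, or a ring carrying methoxy or an amine, would behave at this place.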